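A few compounds are considered here, and "the series" means these few. Any claim that something is new, unique, unknown or untested is made for them only; others in the source may bear on it.

Measured compounds:
compound 1 `COc1ccc(Br)cc1CCc1c(F)cccc1C(=O)/N=C(\N)NCCC1CCCCC1`, which gives 2600 nM in an assay for binding affinity to Melanocortin receptor 4 (Homo sapiens); on this read-out lower numbers stand for stronger inhibition and higher numbers for weaker inhibition;
compound 2 `CCN(CC)CCCC(C)/N=C(/N)NC(=O)c1cccc(F)c1CCc1ccc2ccccc2c1`, which gives 690 nM in this assay.

Compound 1 stands at the higher of these two numbers, with compound 2 below it by a gap beyond the usual scatter. Compound 3 `COc1ccc(Br)cc1CCc1c(F)cccc1C(=O)/N=C(\N)NCCCCN1CCCCC1` differs from compound 1 by 2-(piperidin-1-yl)ethyl in place of cyclohexyl on a saturated chain carbon, two bonds along the chain from an amine nitrogen. Going by the values given here, no measured pair shows this change, so the size of the step in this assay is open; a moderate move toward a lower number is expected, though a step within the scatter cannot be excluded. Compound 3 is therefore expected to give 1200 nM, within 400 nM to 4000 nM. This corresponds to an expected step of a 2.2-fold lower number from compound 1 to compound 3 (0.34 log units; beyond the scatter).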

Compound 3, inhibition constant: 0.58 nM
The estimate for compound 3 lay 2100-fold (3.32 log units) above the measured number; the whole stated range lies above it.
By their numbers in this assay, from the lowest: compound 3; then compound 2; then compound 1.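

In this assay, 2-(piperidin-1-yl)ethyl in place of cyclohexyl on a saturated chain carbon, two bonds along the chain from an amine nitrogen, gives a 4500-fold lower number from compound 1 to compound 3 (3.65 log units; beyond the scatter), a large step. Going by these compounds alone, this is the first one-place change read at this position, and it shows that the number here depends strongly on the group carried there. Nothing shown bears on the cause of the step.

The compounds leave open whether the ring nitrogen or the added chain length carries the step. A 4-cyclohexylbutyl chain or a morpholine ring at this place could separate the two.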